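The compounds below may be only part of what the source reports. "The series", "measured", "known", "first", "only" and "open" are said of these compounds alone.

Compound 1, with structure `COc1ccc2nc(C)cc(OCC(=O)Nc3cc(C)ccc3C)c2c1`, and compound 2, with structure `COc1ccc2nc(C)cc(OCC(=O)Nc3ccc(Cl)c(OC)c3)c2c1`, share one core and differ only in the group on the amide-type nitrogen. In a toxicity assay on HepG2 cells (Homo sapiens) for inhibition, read by CellTiter-Glo, with a stated time of 48 h (on this read-out lower numbers stand for stronger inhibition and higher numbers for weaker inhibition), compound 1 gives > 100000 nM, which is a limit of the assay rather than a number. In this assay compound 2 gives > 100000 nM, again a limit rather than a number. The step that the two limits leave unreadable from compound 1 to compound 2 therefore cannot be read, and compound 2 stands at the limit, as recorded by the limit of > 100000 nM in this assay, at which 2 of the 2 values shown sit.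

Compound 3, with structure `COc1ccc2nc(C)cc(OCC(=O)Nc3ccccn3)c2c1`, is the next compound: pyridin-2-yl in place of 4-chloro-3-methoxyphenyl on an amide-type nitrogen. Among the compounds with values here, the only measured step on this nitrogen is the unreadable one from compound 1 to compound 2, so it gives no size and no direction, and nothing else bears on the change. Given that both measured compounds sit at the limit, compound 3 is expected to show no step beyond the scatter, a number no higher from compound 2 to compound 3 (the limit leaves the size open). For compound 3 the estimated value in this assay is 100000 nM, with an expected range from 30000 nM to 300000 nM.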

Compound 3, half-maximal inhibitory concentration: > 100000 nM
Compound 3: no number, only a limit (the forecaster's own chance of this, stated with the estimate: 85%); the middle value lies on the limit itself.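

In this assay compound 3 gives > 100000 nM, again a limit of the assay and not a number. The steps among compound 1, compound 2 and compound 3 therefore cannot be read, and all three stand at one limit: the limit of > 100000 nM in this assay, at which 3 of the 3 values shown sit. The compounds shown leave open what actual number each would give in this assay, and whether the group on the amide-type nitrogen changes that number at all.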